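The source may report more compounds than this note shows. Statements on the series, on what has been measured and on what is new or still open speak of the compounds shown alone.

Compound 2 `CCNC(=O)[C@H]1OC(n2cnc3c(NC(CC)CC)ncnc32)[C@H](O)[C@@H]1O` gives 1.5 nM in an assay with adenosine receptor A1 (Rattus norvegicus) as the target (a lower number here means a stronger inhibitor, a higher number a weaker inhibitor), the lowest of the two numbers in hand; compound 1 `CCNC(=O)[C@H]1OC(n2cnc3c(NC)ncnc32)[C@H](O)[C@@H]1O` gives 120 nM. Among the compounds with values here, the one step in the set, an 80-fold lower number from compound 1 to compound 2 (1.90 log units; beyond the scatter), is large. Compound 3 `CCNC(=O)[C@H]1OC(n2cnc3c(Nc4ccc(OC)cc4)ncnc32)[C@H](O)[C@@H]1O` differs from compound 2 by 4-methoxyphenyl in place of pentan-3-yl on a nitrogen on an aromatic ring. Within the data shown here, no measured step bears directly on this exchange; the single step from compound 1 to compound 2 concerns a different group at the same nitrogen and shows only that this assay responds strongly to what sits there. For compound 3 a move back toward a higher number is expected, a 20-fold higher number from compound 2 to compound 3 (1.30 log units; beyond the scatter). Compound 3 is estimated at 30 nM, within 5 nM to 200 nM.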

Compound 3, half-maximal inhibitory concentration: 4.6 nM
For compound 3 the middle estimate is 6.5-fold (0.81 log units) above the measured one; the measured number lies below the stated range.
By their numbers in this assay, from the lowest: compound 2; then compound 3; then compound 1.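

In this assay, a 4-methoxyphenyl group on this nitrogen costs little against pentan-3-yl: a 3.1-fold higher number from compound 2 to compound 3 (0.49 log units; beyond the scatter) is modest. Against methyl, a 26-fold lower number from compound 1 to compound 3 (1.42 log units; beyond the scatter) is large, so a lower number than that of compound 1 is reached with both a branched chain without a ring and an aromatic ring in this place. No data at hand give a reason for either step. From the compounds shown here alone, it remains open what the methoxy group contributes, and whether plain phenyl, 4-hydroxyphenyl or cyclopentyl on this nitrogen would give a number nearer that of compound 2 or compound 3.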